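The compounds below may be only part of what the source reports. "The series", "measured", "known", "first", "only" and "open" are said of these compounds alone.

Series notes, halogen position on the core. Compound 2 `CC(=O)NCc1cccc(Cn2nc(NS(=O)(=O)c3ccc(Cl)s3)c3c(F)cccc32)c1` is the weaker of the two measured compounds: in a functional assay on CHO cells for antagonist activity at C-C chemokine receptor type 4 (Homo sapiens), read by GTPgammaS binding (on this read-out lower numbers stand for stronger inhibition and higher numbers for weaker inhibition), compound 2 gives 79.4 nM, and its nearest neighbour, compound 1 `CC(=O)NCc1cccc(Cn2nc(NS(=O)(=O)c3ccc(Cl)s3)c3c(Cl)cccc32)c1`, gives 31.6 nM. Within the data shown here, the one measured step, a 2.5-fold higher number from compound 1 to compound 2 (0.40 log units; beyond the scatter), is the only guide available for this position. The next compound, compound 3 `CC(=O)NCc1cccc(Cn2nc(NS(=O)(=O)c3ccc(Cl)s3)c3c(O)cccc32)c1`, differs from compound 2 by hydroxy in place of fluoro on an aromatic carbon. Among the measured compounds shown here, no measured pair shows what a hydroxy group does here; the step from chloro to fluoro is all that bears on it, and it was modest. The expectation for compound 3 is therefore a small step, not confidently beyond the scatter, set as a 1.3-fold higher number from compound 2 to compound 3 (0.10 log units; within the scatter) in this assay. Compound 3 is accordingly estimated at 100 nM in this assay, with a range of 32 nM to 320 nM to cover the lack of a measured precedent.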

Compound 3, half-maximal inhibitory concentration: 12.6 nM
For compound 3 the middle estimate is 7.9-fold (0.90 log units) above the measured one; measured number outside the range, below it.
By their numbers in this assay, from the lowest: compound 3; then compound 1; then compound 2.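

In this assay this aromatic carbon is not limited to halogens: hydroxy gives the lowest number of the three, with a 6.3-fold lower number from compound 2 to compound 3 (0.80 log units; beyond the scatter) and a 2.5-fold lower number from compound 1 to compound 3 (0.40 log units; beyond the scatter). The chloro-to-fluoro step alone did not show how wide the spread at this place can be, and the larger of these steps comes with the entry of hydroxy, which carries a hydrogen-bond donor and acceptor that are not counted for fluoro. Nothing at hand accounts for the lower number with hydroxy.

The compounds shown leave open whether the lower number is particular to hydroxy or would also appear with another group at this place, such as methoxy or an amine. They also leave open whether the order of hydroxy, chloro and fluoro holds when other parts of the shared core change.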